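A few compounds are considered here, and "the series" means these few. Any claim that something is new, unique, unknown or untested is made for them only; others in the source may bear on it.

Measured so far in a functional assay on MCF7 cells (Homo sapiens) for inhibition, read by MTT assay, with a stated time of 48 h; a lower number here means a stronger inhibitor, a higher number a weaker inhibitor:
- compound 1 `Fc1ccccc1CSc1nnc(-c2ccncc2)n1-c1ccccc1`: > 50000 nM
- compound 2 `Brc1ccccc1CSc1nnc(-c2ccncc2)n1-c1ccccc1`: 16100 nM
- compound 3 `Brc1cccc(CSc2nnc(-c3ccncc3)n2-c2ccccc2)c1`: 10000 nM

The value for compound 1 is a limit of the assay. Compound 3 gives 10000 nM and is not separated from compound 2, since a 1.6-fold lower number from compound 2 to compound 3 (0.21 log units; within the scatter) stays within the scatter.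

Compound 4 `Fc1ccc(CSc2nnc(-c3ccncc3)n2-c2ccccc2)c(F)c1` carries the change (2,4-difluorophenyl in place of 3-bromophenyl on a saturated chain carbon bound to a sulfur), that is, 2,4-difluorophenyl in place of 3-bromophenyl on a saturated chain carbon bound to a sulfur. Going by the values given here, two measured steps bear most directly on this change, both of them moving away from the fluorinated compound 1: an at least 3.1-fold lower number from compound 1 to compound 2 (0.49 log units; beyond the scatter) and an at least 5.0-fold lower number from compound 1 to compound 3 (0.69 log units; beyond the scatter). Both are at least modest and beyond the scatter. Moving the bromine gave no resolved change in this assay, so the swap of halogen is the better guide. The 2,4-difluorophenyl group itself has not been measured, and a single fluorinated compound is thin support. A step of similar modest size towards a higher number is therefore expected, and it may reach the limit.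

The expected step is a 3.2-fold higher number from compound 3 to compound 4 (0.51 log units; beyond the scatter). For compound 4 the estimate is 32000 nM, with an expected range of 13000 nM to 50000 nM.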

Compound 4, half-maximal inhibitory concentration: 14100 nM
Compound 4: the middle estimate sits 2.3-fold (0.36 log units) above what was measured; the range from low to high includes it.
By their numbers in this assay, from the lowest: compounds 3, 4 and 2 (each within the scatter of the next). At a limit, above all of these: compound 1.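

In this assay, the 2,4-difluorophenyl group is not separated from either bromophenyl group, with a 1.4-fold higher number from compound 3 to compound 4 (0.15 log units; within the scatter) and a 1.1-fold lower number from compound 2 to compound 4 (0.06 log units; within the scatter), so fluorine on this ring does not by itself go with a weaker result. The change of fluoro in place of hydrogen on an aromatic carbon gives an at least 3.5-fold lower number from compound 1 to compound 4 (0.54 log units; beyond the scatter), which makes the substitution pattern on this ring matter more than the choice of halogen, though this rests on one pair of compounds. The value of compound 1 is a limit and not a number: the limit of > 50000 nM in this assay, at which 1 of the 4 values shown sits.

Every compound shown carries a halogen on this ring, so it remains open how an amine, a carboxylic acid or a methoxy group there would read. From the compounds shown here alone, a longer chain in place of the benzyl link also remains open, as does whether any change in this position gives a much lower number.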